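The compounds below may be only part of what the source reports. "The series", "measured", "known", "first", "only" and "open" are said of these compounds alone.

Going by the values given here, compound 2, `COc1ccc(Cn2cc(CNC(=O)c3ccc([N+](=O)[O-])o3)nn2)cc1`, is one of two compounds measured in an ADME assay on MRC5 cells (Homo sapiens) for cytotoxicity; on this read-out lower numbers stand for stronger inhibition and higher numbers for weaker inhibition. In this assay compound 2 gives 146000 nM, the lowest of the two numbers, while compound 1, `COc1ccc(Cn2cc(CNC(=O)c3ccc([N+](=O)[O-])o3)nn2)cc1F`, gives 324000 nM. Among the compounds with values here, the one step between them, a 2.2-fold lower number from compound 1 to compound 2 (0.35 log units; beyond the scatter), is the only guide available.

Compound 3, `COc1cc(Cn2cc(CNC(=O)c3ccc([N+](=O)[O-])o3)nn2)ccc1F`, has not yet been measured. It differs from compound 2 in one place: 4-fluoro-3-methoxyphenyl in place of 4-methoxyphenyl on a saturated chain carbon bound to an aromatic nitrogen. Like the step from compound 1 to compound 2 read backwards, this change adds a fluorine to the aromatic ring that hangs from the shared core, although here as part of a differently named group, so the earlier step carries over only loosely.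

Because a 2.2-fold lower number from compound 1 to compound 2 (0.35 log units; beyond the scatter) was modest and just beyond the scatter, the expectation for compound 3 is a shift of similar size in the opposite direction, that is a higher number, with a fair chance that it stays within the scatter. The estimated step from compound 2 to compound 3 is a 1.7-fold higher number from compound 2 to compound 3 (0.23 log units; within the scatter), and compound 3 is expected to give about 250000 nM, with a likely range from 110000 nM to 600000 nM.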

Compound 3, half-maximal inhibitory concentration: 155000 nM
Estimate against measurement, compound 3: 1.6-fold (0.21 log units) above; the measured number falls inside the stated range.
By their numbers in this assay, from the lowest: compounds 2 and 3 (each within the scatter of the next); then compound 1.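

In this assay, 4-fluoro-3-methoxyphenyl in place of 4-methoxyphenyl on a saturated chain carbon bound to an aromatic nitrogen gives a 1.1-fold higher number from compound 2 to compound 3 (0.03 log units; within the scatter), so this assay does not separate these two groups, and the added fluoro does not on its own bring a shift beyond the scatter. The picture differs for the other fluorinated group: 4-fluoro-3-methoxyphenyl in place of 3-fluoro-4-methoxyphenyl gives a 2.1-fold lower number from compound 1 to compound 3 (0.32 log units; beyond the scatter), so among these three compounds the numbers in the group's name matter, and a fluoro on the ring does not by itself go with the higher number seen for compound 1. Nothing given here explains why these two fluorinated groups part ways.

The three groups shown all keep a methoxy on the aromatic ring, so it remains open whether an amine or a carboxylic acid in its place would shift the number beyond the scatter. Also open, as far as these compounds go, is what a longer chain in place of the saturated chain carbon would do, and whether the contrast between the two fluorinated groups would hold in such compounds.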